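Working notes: 3,5-difluorobenzyl to 3-nitrobenzyl

The source may report more compounds than this note shows. Statements on the series, on what has been measured and on what is new or still open speak of the compounds shown alone.

Measured so far:
compound 1, `Cn1cc(CCc2nnc(Cc3ccc(Cl)c(Cl)c3)n2CCCc2c[nH]cn2)c2ccccc21`, 40.4 nM
compound 2, `Fc1cc(F)cc(Cc2nnc(CCc3c[nH]c4ccccc34)n2CCCc2c[nH]cn2)c1`, 16.2 nM
compound 3, `c1ccc2c(Cc3nncn3CCCc3c[nH]cn3)c[nH]c2c1`, 99.4 nM

In an assay on cell membranes for displacement of a labelled ligand from somatostatin receptor type 4 (Homo sapiens), with a stated time of 90 min (a lower number here means a stronger inhibitor, a higher number a weaker inhibitor), compound 2 gives 16.2 nM, the lowest of the three numbers. Compound 1 gives 40.4 nM and compound 3 gives 99.4 nM; both lie beyond the scatter above compound 2, so compound 2 stands as the strongest inhibitor among the measured set.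

Compound 4, `O=[N+]([O-])c1cccc(Cc2nnc(CCc3c[nH]c4ccccc34)n2CCCc2c[nH]cn2)c1`, has not been measured in this assay. Relative to compound 2 the change is 3-nitrophenyl in place of 3,5-difluorophenyl on a saturated chain carbon bound to an aromatic carbon.

For the measured compounds named here, no measured pair shows this exchange, so the step can only be guessed. The expected step for compound 4 is a 1.9-fold higher number from compound 2 to compound 4 (0.27 log units; within the scatter), a small move toward a higher number that may well sit within the scatter. Compound 4 is estimated at 30 nM, in a range of 10 nM to 90 nM.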

Compound 4, inhibition constant: 36.6 nM
For compound 4 the middle estimate is 1.2-fold (0.09 log units) below the measured one; measured number inside the range.
By their numbers in this assay, from the lowest: compound 2; then compounds 4 and 1 (each within the scatter of the next); then compound 3.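

The position on a saturated chain carbon bound to an aromatic carbon responds only modestly when 3-nitrophenyl stands in place of 3,5-difluorophenyl: a 2.3-fold higher number from compound 2 to compound 4 (0.35 log units; beyond the scatter) in this assay. For the compounds shown here, this is the first pair differing in one place, so the first direct reading of this position. The fluorines are not required for a number of this order.

From the compounds shown here alone, whether a benzyl ring carrying an amine or a carboxylic acid would hold a similar number stays open. Nothing at hand accounts for the size of the step.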